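Changing the Amide Side Chain of Compound 1

The source may hold more compounds than are shown below. What is called first, only, known or untested is meant among the compounds shown, and "the series" means these compounds.

In an in vitro ADME assay on microsomes from Gut (Homo sapiens) for metabolic stability, in the presence of a further agent that is not named here (on this read-out higher numbers stand for fast clearance and lower numbers for slow clearance), compound 1 `CC(C)(CO)CNC(=O)c1cc2cc(C#N)ccc2n1Cc1cccc(OC(F)(F)F)c1` gives 136 mL.min-1.g-1 and compound 2 `COc1ccc(OC(F)(F)F)cc1Cn1c(C(=O)NCC(C)(C)CO)cc2cc(C#N)ccc21` gives 68 mL.min-1.g-1. Among the measured compounds shown here, these are the only two numbers available, and they lie within the scatter of each other. Compound 3 `N#Cc1ccc2c(c1)cc(C(=O)NCCC1(O)CCC1)n2Cc1cccc(OC(F)(F)F)c1` keeps the core of compound 1 and changes the amide side chain, with (1-hydroxycyclobutyl)methyl in place of 1-(hydroxymethyl)-1-methylethyl on a saturated chain carbon bound to an amide-type nitrogen. For the measured compounds named here, the one measured step, a 2.0-fold lower number from compound 1 to compound 2 (0.30 log units; within the scatter), is a methoxy in place of hydrogen on an aromatic carbon, a different change at a different place, and it offers no direct guide to this swap. Going by the values given here, no measured compound carries the new side chain, so no shift beyond the scatter is expected in either direction. The expected step is a 1.1-fold lower number from compound 1 to compound 3 (0.05 log units; within the scatter). In this assay compound 3 is estimated at 120 mL.min-1.g-1, with an expected range from 50 mL.min-1.g-1 to 280 mL.min-1.g-1.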

Compound 3, intrinsic clearance in microsomes: < 6 mL.min-1.g-1
Compound 3: a limit, no number (the forecaster's own chance of this, stated with the estimate: 5%); at least 20-fold (1.30 log units) between middle value and limit.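

At the saturated chain carbon bound to an amide-type nitrogen, the side chain matters strongly in this assay: (1-hydroxycyclobutyl)methyl in place of 1-(hydroxymethyl)-1-methylethyl gives an at least 22-fold lower number from compound 1 to compound 3 (1.35 log units; beyond the scatter). The only earlier step lay at a different place and stayed within the scatter, so this is the first change shown that goes beyond it. For compound 3 the read-out is a limit and not a number, so the step gives only a bound: the limit of < 6 mL.min-1.g-1 in this assay, at which 1 of the 3 values shown sits.

As far as these compounds go, with only compound 3 carrying the new side chain, it stays open which part of (1-hydroxycyclobutyl)methyl goes with the step, and whether a cyclopropyl or cyclopentyl ring, or an amine in place of the hydroxyl, would give a similar read-out. Also open, from the compounds shown here alone, is how the methoxy of compound 2 would behave together with this side chain.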